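The source may report more compounds than this note shows. Statements on the series, on what has been measured and on what is new or still open speak of the compounds shown alone.

Measured compounds:
compound 1, `O=C(O)CSC(CC(=O)c1ccccc1)C(=O)O` — 15000 nM
compound 2, `CCCCc1ccc(C(=O)CC(SCC(=O)O)C(=O)O)cc1` — 1910 nM
compound 3, `CC(C)(C)c1ccc(C(=O)CC(SCC(=O)O)C(=O)O)cc1` — 1390 nM

In a functional assay on HeLa cells (Homo sapiens) (a lower number here means a stronger inhibitor, a higher number a weaker inhibitor), compound 3 holds the lowest number of the three, but compound 2 lies within the scatter of it (a 1.4-fold lower number from compound 2 to compound 3 (0.14 log units; within the scatter)), so the two cannot be ordered; only compound 1 stands clearly apart, with the step of an 11-fold lower number from compound 1 to compound 3 (1.03 log units; beyond the scatter) and, to compound 2, a 7.9-fold lower number from compound 1 to compound 2 (0.90 log units; beyond the scatter).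

Compound 4, `O=C(O)CSC(CC(=O)c1ccc(F)cc1)C(=O)O`, differs from compound 3 by fluoro in place of tert-butyl on an aromatic carbon. Among the measured compounds shown here, the steps that bear on this change are a 7.9-fold lower number from compound 1 to compound 2 (0.90 log units; beyond the scatter) and an 11-fold lower number from compound 1 to compound 3 (1.03 log units; beyond the scatter): both show that replacing hydrogen at this carbon by butyl or tert-butyl lowers the number well beyond the scatter, while the exchange of the two larger groups (a 1.4-fold lower number from compound 2 to compound 3 (0.14 log units; within the scatter)) stays within it. For the measured compounds named here, no compound with fluoro at this carbon has been measured, and the entering group contributes far fewer atoms than the one it replaces, as fluoro in place of tert-butyl on an aromatic carbon sets out, so the gain seen for compound 3 over compound 1 is expected to be largely lost. The step from compound 3 to compound 4 is therefore expected to be a 6.5-fold higher number from compound 3 to compound 4 (0.81 log units; beyond the scatter), back toward the number of compound 1. Compound 4 is estimated at 9000 nM, with a range of 3000 nM to 25000 nM.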

Compound 4, half-maximal inhibitory concentration: 20700 nM
The estimate for compound 4 lay 2.3-fold (0.36 log units) below the measured number, and the stated range covers the measured number.
By their numbers in this assay, from the lowest: compounds 3 and 2 (each within the scatter of the next); then compounds 1 and 4 (each within the scatter of the next).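

Working from this assay, the gain at this aromatic carbon proves reversible: fluoro in place of tert-butyl gives a 15-fold higher number from compound 3 to compound 4 (1.17 log units; beyond the scatter) and fluoro in place of butyl gives an 11-fold higher number from compound 2 to compound 4 (1.03 log units; beyond the scatter) as the two steps of comparable size, so the lower numbers of the series so far belong to those two carbon groups and do not come from substitution at this carbon as such. Fluoro in place of hydrogen gives a 1.4-fold higher number from compound 1 to compound 4 (0.14 log units; within the scatter) as its step, so at this carbon the change from hydrogen to fluoro cannot be told from no change, and the series now holds one substituent that lowers nothing alongside two that do. What sets fluoro apart from butyl and tert-butyl here is a matter on which no supporting measurement is available.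

Open, going by these compounds, is whether a smaller carbon group such as methyl or ethyl keeps part of the gain seen with butyl and tert-butyl, and whether a longer chain such as hexyl, or a methoxy or trifluoromethyl group, at the same carbon lowers the number further. Also open, on these data alone, is how far either carboxylic acid of the shared core can be exchanged, for example for an amide or an ester, while the tert-butyl group stays in place.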